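From an Isopentyl Ester to a Phenethyl Thioester

The source may hold more compounds than are shown below. What is called first, only, known or untested is meant among the compounds shown, and "the series" means these compounds.

Three compounds have been measured in a functional assay on SK-BR-3 cells (Homo sapiens) for antiproliferative activity, read by MTT assay, with a stated time of 72 h; on this read-out lower numbers stand for stronger inhibition and higher numbers for weaker inhibition:

Compound 1 `C/C=C1/[C@H](O[C@@H]2O[C@H](COC(C)=O)[C@@H](OC(C)=O)[C@H](OC(C)=O)[C@H]2OC(C)=O)OC=C(C(=O)OC)[C@H]1CC(=O)OCCC` gives 6600 nM.
Compound 2 `C/C=C1/[C@H](O[C@@H]2O[C@H](COC(C)=O)[C@@H](OC(C)=O)[C@H](OC(C)=O)[C@H]2OC(C)=O)OC=C(C(=O)OC)[C@H]1CC(=O)OC` gives > 15000 nM, which is a limit of the assay rather than a number.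
Compound 3 `C/C=C1/[C@H](O[C@@H]2O[C@H](COC(C)=O)[C@@H](OC(C)=O)[C@H](OC(C)=O)[C@H]2OC(C)=O)OC=C(C(=O)OC)[C@H]1CC(=O)OCCC(C)C` gives > 15000 nM, again a limit of the assay.

The three share one core and differ only in the ester on its side chain. The step of an at least 2.2-fold higher number from compound 1 to compound 2 (0.35 log units; beyond the scatter) and the step of an at least 2.2-fold higher number from compound 1 to compound 3 (0.35 log units; beyond the scatter) both lead away from compound 1 to weaker inhibition. The step that the two limits leave unreadable from compound 2 to compound 3 cannot be sized. Compound 3 stands at the limit of > 15000 nM in this assay, at which 2 of the 3 values shown sit.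

Compound 4 `C/C=C1/[C@H](O[C@@H]2O[C@H](COC(C)=O)[C@@H](OC(C)=O)[C@H](OC(C)=O)[C@H]2OC(C)=O)OC=C(C(=O)OC)[C@H]1CC(=O)SCCc1ccccc1` changes that ester: phenethylsulfanyl in place of isopentyloxy on a carbonyl carbon. For the measured compounds named here, no measured step involves a sulfur in this position or an aromatic ring, so the measured steps only show that lengthening the chain, as from compound 1 to compound 3, cost activity, and they give no direct guide to a thioester. Compound 4 is therefore expected near 12000 nM, within 4000 nM to 30000 nM. That estimate means an expected step of an at least 1.2-fold lower number from compound 3 to compound 4 (0.09 log units; that floor lies within the scatter), likely ending at the limit again.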

Compound 4, half-maximal inhibitory concentration: > 15000 nM
Compound 4 was reported as a limit; the forecaster's own chance of this, stated with the estimate: 55%; at least 1.2-fold (0.09 log units) between middle value and limit.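

In this assay compound 4 gives > 15000 nM, which is a limit of the assay and not a number. Placing phenethylsulfanyl on this carbonyl carbon, and so bringing in a sulfur and an aromatic ring, does not give a measurable value here, and the comparison with the propoxy group shows an at least 2.2-fold higher number from compound 1 to compound 4 (0.35 log units; beyond the scatter). The steps from compound 2 and compound 3 to compound 4 cannot be read, and compound 1 remains the only compound of the four with a measured number, the rest sitting at one limit: the limit of > 15000 nM in this assay, at which 3 of the 4 values shown sit.

Compound 4 brings in the sulfur and the aromatic ring together, so the shift cannot be assigned to either one alone. On these data alone, a propylsulfanyl group or a phenethyloxy group on the same carbonyl carbon would pull the two apart, and how either would behave remains open.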